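A few compounds are considered here, and "the series" means these few. Any claim that something is new, unique, unknown or untested is made for them only; others in the source may bear on it.

Measured so far:
compound 1, `CSc1ccc(NC(=O)Nc2cc(C)nc3ccccc23)cc1`, in an ADME assay on HepG2 cells (Homo sapiens) for cytotoxicity, with a stated time of 72 h; on this read-out higher numbers stand for an effect only at larger amounts of compound and lower numbers for an effect already at smaller amounts: 16000 nM
compound 2, `Cc1cc(NC(=O)Nc2cc(Cl)cc(Cl)c2)c2ccccc2n1`, in this assay: > 25000 nM, a limit of the assay rather than a number

Among the measured compounds shown here, compound 1 stands as the only compound with an actual number in this assay; the other value shown is a limit. For the measured compounds named here, for compound 2 the limit is described by the limit of > 25000 nM in this assay, at which 1 of the 2 values shown sits, so no step between two measured compounds can be drawn here, and compound 2 can only be said to sit at that limit.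

Compound 3, `Cc1cc(NC(=O)Nc2ccc(O)cc2)c2ccccc2n1`, is the next compound to be tested in this assay. It differs from compound 1 in one place: hydroxy in place of methylsulfanyl on an aromatic carbon. Going by the values given here, no measured step of this kind is available to lean on. Among the compounds with values here, with only the single number of compound 1 to start from, the step in this assay from compound 1 to compound 3 is expected to be small, within the usual scatter or at most a modest move toward higher values. Compound 3 is therefore expected to give about 20000 nM, with a likely range from 8000 nM to 30000 nM. The step of a 1.3-fold higher number from compound 1 to compound 3 (0.10 log units; within the scatter) is thus the estimate, before any measurement is known.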

Compound 3, half-maximal effective concentration: > 25000 nM
Compound 3: only a limit was reported (the forecaster's own chance of this, stated with the estimate: 45%); middle value at least 1.2-fold (0.09 log units) from the limit.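

Hydroxy in place of methylsulfanyl, on an aromatic carbon para to a large group, gives the first step between two compounds that differ in one place: an at least 1.5-fold higher number from compound 1 to compound 3 (0.19 log units; that floor lies within the scatter) in this assay. Compound 3 carries a limit and not a number, so this step is only a floor, and the true gap could lie either within the scatter or beyond it. What can be said is that this change does not shift the effect toward smaller amounts of compound, and compound 1 remains the only compound with a readable number: the limit of > 25000 nM in this assay, at which 2 of the 3 values shown sit.

The compounds shown leave open how far the value of compound 3 lies from compound 1, and so whether this position matters to the read-out at all. They also leave open whether an amine, a carboxylic acid or a methoxy group at this position, on the same core, would give a number in this assay or would again end at the limit.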